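The source may hold more compounds than are shown below. What is called first, only, known or untested is meant among the compounds shown, and "the series" means these compounds.

Compound 1 `O=C(/C=C/c1ccc(I)cc1)c1ccc(OCB(O)O)cc1` — 38000 nM
Compound 2 `O=C(/C=C/c1ccccc1)c1ccc[nH]1` — 63000 nM
Compound 3 `O=C(O)COc1ccc(/C=C/C(=O)c2ccc(Cl)c(Cl)c2)cc1` — 12000 nM

In a functional assay on MCF-10A cells (Homo sapiens) for inhibition (a lower number here means a stronger inhibitor, a higher number a weaker inhibitor), compound 3 gives the lowest number of the three; compound 1 stands a step beyond the scatter above it, compound 2 further still. Among the measured compounds shown here, no pair that differs in only one place has been measured, so no single step is known. Compound 4 `O=C(/C=C/c1ccc(B(O)O)cc1)c1ccc(Cl)c(Cl)c1` remains to be measured. It differs from compound 3 as follows: a group of 3 heavy atoms (1 boron, 2 oxygen; no ring) in place of a group of 5 heavy atoms (2 carbon, 3 oxygen; no ring), on an aromatic carbon. Compound 1 also carries a boron group, on the other ring, and gives a higher number than compound 3, but the two differ in more than one place, so this shows little. In this assay a small step is expected, a 1.3-fold higher number from compound 3 to compound 4 (0.10 log units; within the scatter), in no sure direction. Compound 4 is estimated at 15000 nM, with a range from 5000 nM to 45000 nM.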

Compound 4, half-maximal inhibitory concentration: 18000 nM
Estimate against measurement, compound 4: 1.2-fold (0.08 log units) below; low and high end bracket the measured number.
By their numbers in this assay, from the lowest: compounds 3 and 4 (each within the scatter of the next); then compounds 1 and 2 (each within the scatter of the next).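

In this assay, the step from the carboxymethoxy group to a boron group of 3 heavy atoms, on an aromatic carbon para to a large group, is a 1.5-fold higher number from compound 3 to compound 4 (0.18 log units; within the scatter) and gives the series its first single-place reading at this position. This exchange therefore leaves the number within the scatter, despite the change in heavy-atom count. No measurement here accounts for this result.

An amine or a longer chain at this position remains untested in the compounds shown. Also open, as far as these compounds go, is whether the exchange reads the same with the two chlorines replaced.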